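Swapping a Ring Substituent on a Shared Core

The source may report more compounds than this note shows. Statements on the series, on what has been measured and on what is new or still open speak of the compounds shown alone.

Of the compounds shown here, two with a shared core have been measured so far. Compound 1, `Nc1scc(CN2CCN(c3ccc(Cl)cc3F)CC2)c1C(=O)c1ccc(Cl)cc1`, carries a 4-chloro-2-fluorophenyl group on an amine nitrogen in a ring; in an assay on CHO cells for displacement of a labelled ligand from adenosine receptor A1 (Homo sapiens), read by scintillation counting, with a stated time of 120 min, tested at 10 uM (on this read-out lower numbers stand for less inhibition and higher numbers for more inhibition at the one concentration tested (going by the name of the read-out)), compound 1 gives 0%. Compound 2, `Nc1scc(CN2CCN(C3CCCCCC3)CC2)c1C(=O)c1ccc(Cl)cc1`, carries a cycloheptyl group on that amine nitrogen in a ring, and in this assay compound 2 gives 0%. The step of no change at the digits printed from compound 1 to compound 2 (within the scatter) shows that exchanging the aromatic group for the seven-membered non-aromatic ring made no difference that rises above the scatter. Compound 2 thus stands level with compound 1, and both sit at the bottom of what the read-out can show.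

Compound 3, `Nc1scc(CN2CCN(c3cccc(F)c3)CC2)c1C(=O)c1ccc(Cl)cc1`, differs from compound 2 in one place: 3-fluorophenyl in place of cycloheptyl on an amine nitrogen in a ring. Among the measured compounds shown here, the only measured step that bears on this change is the one from compound 1 to compound 2, which exchanged an aromatic ring for cycloheptyl without effect; compound 3 brings back an aromatic ring. Because no change at the digits printed from compound 1 to compound 2 (within the scatter) showed nothing, no step beyond the scatter is expected here. The expected step of no change at the digits printed from compound 2 to compound 3 (within the scatter) is therefore essentially none. Compound 3 is estimated to give 0% in this assay, with a range from -8% to 15%.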

Compound 3, a percentage reported as inhibition, at one concentration (the size of the read-out at that concentration, not a potency): 1%
Compound 3: the middle estimate sits 1 percentage points below what was measured; the measured number falls inside the stated range.
By their numbers in this assay, from the lowest: compounds 1, 2 and 3 (each within the scatter of the next).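

Replacing cycloheptyl with 3-fluorophenyl on the amine nitrogen in a ring gives a number 1 percentage points higher from compound 2 to compound 3 (within the scatter) in this assay, so an aromatic ring carrying a single fluorine reads no differently here from the seven-membered non-aromatic ring of carbon only. The comparison between the two aromatic groups adds a second point, since 3-fluorophenyl in place of 4-chloro-2-fluorophenyl gives a number 1 percentage points higher from compound 1 to compound 3 (within the scatter), and this change in the halogens on the phenyl ring does not lift the result out of the scatter either. All three groups at this position therefore remain level near the bottom of the read-out, and no measurement is available to explain why they read alike.

With all three values so close to the floor, these compounds do not show whether any group on this nitrogen can produce a clear reading at the one concentration tested. Open questions include how a benzyl group, a pyridine ring or a short alkyl chain such as methyl would read on the same nitrogen, and whether the same holds with a different group in place of the chlorophenyl ketone of the shared core.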